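Ether chain variation on the aminoquinoline-type core

The compounds below may be only part of what the source reports. "The series", "measured", "known", "first", "only" and "open" are said of these compounds alone.

Measured compounds:
compound 1 `Nc1ccc2cccc(OCC3CCCC3)c2n1` — 53 nM
compound 2 `CC(CC(C)(C)C)Oc1cccc2ccc(N(C)C)nc12` — > 2000 nM
compound 3 `CNc1ccc2cccc(OC(C)CC(C)(C)C)c2n1` — 310 nM

In an assay on cells with melanin-concentrating hormone receptor 1 (Homo sapiens) as the target, read by radioligand binding (a higher number here means a weaker inhibitor, a lower number a stronger inhibitor), compound 1 gives 53 nM, the lowest of the two numbers read; the nearest is compound 3 with 310 nM, a gap beyond the scatter. For compound 2 (the limit of > 2000 nM in this assay, at which 1 of the 3 values shown sits), a limit, not a number. For the measured compounds named here, the one measured step, an at least 6.4-fold lower number from compound 2 to compound 3 (0.80 log units; beyond the scatter), concerns the aromatic amine and not the ether chain.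

Compound 4 `CCC#CCOc1cccc2ccc(N)nc12` differs from compound 1 in the ether chain only: but-1-yn-1-yl in place of cyclopentyl on a saturated chain carbon bound to an oxygen on an aromatic ring. Going by the values given here, no measured step bears on this change; compounds 1 and 3 differ in both the amine and the chain, so their values cannot be split between the two. A step of at most modest size is therefore expected, direction uncertain, a 2.5-fold higher number from compound 1 to compound 4 (0.39 log units; beyond the scatter). For compound 4 the estimate in this assay is 130 nM, between 35 nM and 500 nM.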

Compound 4, half-maximal inhibitory concentration: > 2000 nM
Compound 4 was reported as a limit; the forecaster's own chance of this, stated with the estimate: 5%; middle value at least 15-fold (1.18 log units) from the limit.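

In this assay the ether chain is a sensitive position: with the amine unchanged, but-1-yn-1-yl in place of cyclopentyl gives an at least 37-fold higher number from compound 1 to compound 4 (1.57 log units; beyond the scatter). For the compounds shown here, this is the only measured step on the chain, and it shows that the chain alone can decide binding on the shared core. Compound 4 is reported as a limit, not a number, and the full size of the step stays open: the limit of > 2000 nM in this assay, at which 2 of the 4 values shown sit.

On these data alone, whether the loss follows the removal of the ring or the arrival of the triple bond stays open. A saturated pentyl chain on the same core would separate the two.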